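The source may report more compounds than this note shows. Statements on the series, on what has been measured and on what is new or still open speak of the compounds shown alone.

Compound 1 `CC1(C)[C@H]2CC[C@]1(C)N(Cc1cn(-c3cccc(C#N)c3)nn1)C(=O)C2` gives 440 nM
Compound 2 `CC1(C)[C@H]2CC[C@]1(C)N(Cc1cn(-c3ccccc3Cl)nn1)C(=O)C2` gives 70 nM
Compound 3 `CC1(C)[C@H]2CC[C@]1(C)N(Cc1cn(-c3ccc(O)cc3)nn1)C(=O)C2` gives 140 nM

All three values come from a functional assay on A549 cells (Homo sapiens) for inhibition, read by MTT assay, with a stated time of 24 h; on this read-out higher numbers stand for weaker inhibition and lower numbers for stronger inhibition. Compound 3 stands in the lower part of this small set. The comparison with the highest number is a 3.1-fold lower number from compound 1 to compound 3 (0.50 log units; beyond the scatter), and the other comparison is a 2.0-fold higher number from compound 2 to compound 3 (0.30 log units; within the scatter).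

Compound 4 `CC1(C)[C@H]2CC[C@]1(C)N(Cc1cn(-c3cccc(O)c3)nn1)C(=O)C2` has the same atoms as compound 3 but joined differently, with 3-hydroxyphenyl in place of 4-hydroxyphenyl on an aromatic nitrogen. Within the data shown here, no measured pair shows the effect of moving a hydroxyl group alone, so the evidence is indirect. Replacing this aromatic group with a different one gave only modest steps, the largest being a 6.3-fold lower number from compound 1 to compound 2 (0.80 log units; beyond the scatter). A swap that keeps the same atoms is therefore expected to give a step no larger than that. The expected step is a 1.3-fold higher number from compound 3 to compound 4 (0.11 log units; within the scatter), slightly upward if anything and not beyond the scatter. For compound 4 the estimated value is 180 nM, with an expected range from 70 nM to 450 nM.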

Compound 4, half-maximal inhibitory concentration: 180 nM
Estimate against measurement, compound 4: no gap at the digits printed, within the range that was stated.
By their numbers in this assay, from the lowest: compounds 2, 3 and 4 (each within the scatter of the next, the first and the last beyond it); then compound 1.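

In this assay, the step of a 1.3-fold higher number from compound 3 to compound 4 (0.11 log units; within the scatter) stays within the scatter, so 3-hydroxyphenyl and 4-hydroxyphenyl cannot be told apart on this aromatic nitrogen. The group itself matters more here than this shift of the hydroxyl: with hydroxy in place of cyano on an aromatic carbon, the result is a 2.4-fold lower number from compound 1 to compound 4 (0.39 log units; beyond the scatter), a step beyond the scatter. Compound 3 lies within the scatter of compound 2, yet the step of a 2.6-fold higher number from compound 2 to compound 4 (0.41 log units; beyond the scatter) lies beyond it, which shows how small differences within the scatter can add up to a clear gap across the set.

Nothing measured here explains why these groups differ. On these data alone, whether a methoxy group or an amine in place of the hydroxyl would keep the number close to that of compound 4 remains open.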